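This account rests on a few compounds, and the source may have more. Where it says the series, first, only, none or still open, it means among the compounds named here.

Of the compounds shown here, three have been measured in a toxicity assay on HepG2 cells (Homo sapiens) for inhibition, read by CellTiter-Glo, with a stated time of 48 h; on this read-out lower numbers stand for stronger inhibition and higher numbers for weaker inhibition. Compound 1 `Cc1cc(C)cc(NC(=O)COc2cc(C)nc3ccc(F)cc23)c1` gives 63100 nM in this assay. Compound 2 `COc1ccc2nc(C)c(NC(=O)C(=O)Nc3cc(C)cc(C)c3)c(O)c2c1` returns only a limit in this assay, namely > 100000 nM. Compound 3 `COc1ccc2nc(C)cc(OCC(=O)Nc3cc(C)ccc3OC)c2c1` likewise returns only a limit, > 100000 nM, so no number is known for it. Compound 3 therefore stands at the limit of > 100000 nM in this assay, at which 2 of the 3 values shown sit, and its relation to compound 1 cannot be read as a step. Compound 4 `COc1ccc2nc(C)cc(OCC(=O)Nc3ccncc3)c2c1` has not yet been measured in this assay; it differs from compound 3 by pyridin-4-yl in place of 2-methoxy-5-methylphenyl on an amide-type nitrogen. Among the measured compounds shown here, with no measured step to build on, compound 4 is expected to move by no more than the scatter, as a number no higher from compound 3 to compound 4 (the limit leaves the size open). Compound 4 is estimated at 100000 nM, within 40000 nM to 250000 nM, most likely again reported only as a limit.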

Compound 4, half-maximal inhibitory concentration: > 100000 nM
Compound 4 gave a limit, no number; the forecaster's own chance of this, stated with the estimate: 70%; the middle value sits exactly at the limit.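

Compound 3 and compound 4 each return only a limit in this assay, so no step can be read between them: the limit of > 100000 nM in this assay, at which 3 of the 4 values shown sit.

The compounds shown leave open whether pyridin-4-yl in place of 2-methoxy-5-methylphenyl on an amide-type nitrogen changes the inhibition at all.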